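The source may hold more compounds than are shown below. What is called first, only, known or untested is meant among the compounds shown, and "the series" means these compounds.

In a functional assay on CHO cells for positive allosteric modulation of metabotropic glutamate receptor 2 (Homo sapiens), with a stated time of 30 min (a lower number here means that less compound is needed, a higher number that more compound is needed for the effect), compound 2 `CC(C)CCn1ccc(N2CCC(c3ccccc3)CC2)c(C#N)c1=O` gives 102 nM. Compound 1 `CC(C)CCn1ccc(N(C)Cc2ccccc2)c(C#N)c1=O` gives 10700 nM in this assay. Compound 3 `CC(C)CCn1ccc(N2CCCC(c3ccccc3)C2)c(C#N)c1=O` gives 3310 nM in this assay, the second highest of the three numbers: more of it is needed than of compound 2 and less than of compound 1. Compound 4 `CC(C)CCn1ccc(N2CCCCC2)c(C#N)c1=O` differs from compound 3 in one place: hydrogen in place of phenyl on a saturated ring carbon. For the measured compounds named here, no measured pair here shows this change on its own. The two compounds with the lower numbers, compound 2 at 102 nM and compound 3, both carry a phenyl on the saturated ring, so its removal is expected to raise the number well beyond the scatter, by an estimated 4.5-fold higher number from compound 3 to compound 4 (0.66 log units; beyond the scatter). Compound 4 is therefore expected to give about 15000 nM in this assay, within a range from 4000 nM to 60000 nM.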

Compound 4, half-maximal effective concentration: 31600 nM
Compound 4: the middle estimate sits 2.1-fold (0.32 log units) below what was measured; the measured number falls inside the stated range.
By their numbers in this assay, from the lowest: compound 2; then compound 3; then compound 1; then compound 4.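

In this assay, removing the phenyl from the saturated ring gives a 9.5-fold higher number from compound 3 to compound 4 (0.98 log units; beyond the scatter), the first direct view of this change on its own. The same change gives a 310-fold higher number from compound 2 to compound 4 (2.49 log units; beyond the scatter), so the phenyl contributes in both compounds, and far more in compound 2, where it sits elsewhere on the ring. No available evidence explains either step. The compounds shown leave open whether a smaller group such as methyl, or a pyridine ring, could stand in for the phenyl and keep the number low.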